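Replacing a bare hydrogen with a substituted aryl group

The source may report more compounds than this note shows. Statements on the series, on what has been measured and on what is new or still open speak of the compounds shown alone.

Compound 3 `O=C(O)CCNC(=O)[C@@H]1CCCN1S(=O)(=O)c1cc(Cl)cc(Cl)c1` gives 1510 nM in an assay on RPMI-8866 cells for inhibition of integrin alpha-4/beta-1 (Homo sapiens) (a higher number here means a weaker inhibitor, a lower number a stronger inhibitor), the highest of the three numbers measured; compound 2 `CC(C)[C@H](CC(=O)O)NC(=O)[C@@H]1CCCN1S(=O)(=O)c1cc(Cl)cc(Cl)c1` gives 362 nM and compound 1 `C/C=C/[C@@H](CC(=O)O)NC(=O)[C@@H]1CCCN1S(=O)(=O)c1cc(Cl)cc(Cl)c1` gives 13 nM. Compound 4 `CS(=O)(=O)c1ccc([C@@H](CC(=O)O)NC(=O)[C@@H]2CCCN2S(=O)(=O)c2cc(Cl)cc(Cl)c2)cc1` differs from compound 3 by 4-(methylsulfonyl)phenyl in place of hydrogen on a saturated chain carbon bound to an amide-type nitrogen and a saturated chain carbon. For the measured compounds named here, two measured steps touch this same position and both run the other way, toward hydrogen: a 4.2-fold higher number from compound 2 to compound 3 (0.62 log units; beyond the scatter) and a 120-fold higher number from compound 1 to compound 3 (2.07 log units; beyond the scatter). Both show that a substituent at this position strengthens inhibition, with size depending on the group, so a sizeable step toward a lower number is expected for compound 4, a 25-fold lower number from compound 3 to compound 4 (1.40 log units; beyond the scatter), though the entering group matches neither measured one. Compound 4 is therefore estimated at 60 nM, within a range from 8 nM to 500 nM.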

Compound 4, half-maximal inhibitory concentration: 0.55 nM
Compound 4: the middle estimate sits 110-fold (2.04 log units) above what was measured; the whole stated range lies above it.
By their numbers in this assay, from the lowest: compound 4; then compound 1; then compound 2; then compound 3.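

An aryl group fits this position and does far more than the small chains: 4-(methylsulfonyl)phenyl in place of hydrogen gives a 2700-fold lower number from compound 3 to compound 4 (3.44 log units; beyond the scatter) and so exceeds both earlier steps to hydrogen. It also outdoes prop-1-en-1-yl, the best earlier group, with a 24-fold lower number from compound 1 to compound 4 (1.37 log units; beyond the scatter) as the result of that exchange. Nothing measured here explains this gain. The compounds shown leave open how much of it belongs to the phenyl ring and how much to the methylsulfonyl group. A plain phenyl or a 4-aminophenyl group at this position would separate the two.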